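Adding one methyl to compound 1

The source may report more compounds than this note shows. Statements on the series, on what has been measured and on what is new or still open speak of the compounds shown alone.

Among the compounds with values here, in a functional assay on HCT-116 cells (Homo sapiens) for cytotoxicity, read by MTT assay, with a stated time of 72 h (on this read-out higher numbers stand for weaker inhibition and lower numbers for stronger inhibition), compound 1 (`Nc1ccccc1NC(=O)c1ccc(NC(=S)NCc2cccnc2)cc1`) gives 1000 nM as the lower of the two numbers so far, while compound 2 (`Nc1ccccc1NC(=O)c1ccc(NC(=O)NCc2cccnc2)cc1`) gives 9400 nM as the other, a gap beyond the scatter. Compound 3 (`Cc1ccc(CNC(=S)Nc2ccc(C(=O)Nc3ccccc3N)cc2)cn1`) has not yet been measured in this assay. It carries methyl in place of hydrogen on an aromatic carbon, turning pyridin-3-yl into 6-methylpyridin-3-yl, with the methyl next to the ring nitrogen. Within the data shown here, no measured pair shows a change at this place, so the expectation rests on compound 1 alone, at 1000 nM in this series. The expected no change at the digits printed from compound 1 to compound 3 (within the scatter) stays within the scatter, with neither direction favoured. For compound 3 the estimated value is 1000 nM, with an expected range from 400 nM to 2500 nM on repeated measurement.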

Compound 3, half-maximal inhibitory concentration: 11000 nM
For compound 3 the middle estimate is 11-fold (1.04 log units) below the measured one; measured number outside the range, above it.
By their numbers in this assay, from the lowest: compound 1; then compounds 2 and 3 (each within the scatter of the next).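

In this assay, a single methyl on an aromatic carbon next to the ring nitrogen, turning pyridin-3-yl into 6-methylpyridin-3-yl, gives an 11-fold higher number from compound 1 to compound 3 (1.04 log units; beyond the scatter) on this read-out. This is the only step shown at this place, and it marks the position as sensitive: one added carbon, with no ring and no hydrogen-bond donors or acceptors, moves the number well beyond the scatter towards weaker inhibition.

On these data alone, whether this step is particular to methyl or would also follow from another group on the same carbon, such as an amine, a fluorine or a methoxy group, remains open, as does the effect of a methyl on another carbon of the ring. Nothing measured here accounts for the size of the step.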